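Swapping a methylphenyl for a difluorophenyl on the core

The source may report more compounds than this note shows. Statements on the series, on what has been measured and on what is new or still open speak of the compounds shown alone.

Measured so far:
- compound 1, `CC#CC(CC(=O)O)c1ccc(OCc2ccc3nc(-c4ccc(OC)cc4)cn3c2)cc1`: 47 nM
- compound 2, `CC#CC(CC(=O)O)c1ccc(OCc2ccn3cc(-c4ccc(C)cc4)nc3c2)cc1`: 618 nM

Both compounds carry the same acid-bearing side chain and differ in the fused two-ring core and in the aryl group attached to it. In an assay on isolated protein for agonist activity at Free fatty acid receptor 1 (Homo sapiens) (on this read-out lower numbers stand for an effect already at smaller amounts and higher numbers for an effect only at larger amounts of compound), compound 1 gives 47 nM, while compound 2 gives 618 nM. Of the two numbers, that of compound 2 is the higher one, and the gap between them lies beyond the usual scatter of the measurement. Because the two compounds differ in more than one place, the gap cannot be traced to a single change.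

Compound 3, `CC#CC(CC(=O)O)c1ccc(OCc2ccn3cc(-c4ccc(F)cc4F)nc3c2)cc1`, keeps the core of compound 2 and changes only the pendant aryl group: 2,4-difluorophenyl in place of 4-methylphenyl on an aromatic carbon. Among the compounds with values here, no single-place step between measured compounds is available to guide this change, so the expectation rests on compound 2 alone. A modest shift toward a lower number is expected, with a 1.5-fold lower number from compound 2 to compound 3 (0.19 log units; within the scatter) as the estimated step, though a result within the scatter of compound 2 would not be surprising. For compound 3 the estimated value in this assay is 400 nM, expected to fall between 120 nM and 1500 nM.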

Compound 3, half-maximal effective concentration: 792 nM
The estimate for compound 3 lay 2.0-fold (0.30 log units) below the measured number; measured number inside the range.
By their numbers in this assay, from the lowest: compound 1; then compounds 2 and 3 (each within the scatter of the next).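

In this assay, within the data shown here, putting 2,4-difluorophenyl in place of 4-methylphenyl on this aromatic carbon gives a 1.3-fold higher number from compound 2 to compound 3 (0.11 log units; within the scatter) and provides the first comparison here in which only one place differs. On the core shared by these two compounds, this read-out therefore does not tell the two aryl groups apart, so this particular exchange on the ring attached at this position leaves the number unchanged within the usual scatter. No measurement shown here bears on why the two groups read alike.

From the compounds shown here alone, compound 1 still differs from compound 2 and compound 3 in more than one place, so it remains open whether its core, its aryl group or both together account for the gap, and placing the aryl group of compound 1 on the core of compound 2 would separate these. Going by these compounds, it is also open whether this position would respond to a different kind of substituent on the phenyl ring, such as an amine, a carboxylic acid or a longer chain.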